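Swapping a Methoxyphenyl Arm for Trimethoxyphenyl

The compounds below may be only part of what the source reports. "The series", "measured", "known", "first", "only" and "open" are said of these compounds alone.

Measured compounds in a functional assay on SW480 cells (Homo sapiens) for antiproliferative activity; on this read-out lower numbers stand for stronger inhibition and higher numbers for weaker inhibition:
compound 1 `COc1cccc(/C=C/C(=O)c2ccc(OCCn3cc(CN4C(=O)/C=C/C(C)(C)C/C=C(\C)CC/C=C/4C)nn3)cc2O)c1` gives 0.95 ug/mL
compound 2 `COc1cc(/C=C/C(=O)c2ccc(OCCn3cc(CN4C(=O)/C=C/C(C)(C)C/C=C(\C)CC/C=C/4C)nn3)cc2O)cc(OC)c1OC` gives 2.61 ug/mL
compound 3 `COc1ccc(/C=C/C(=O)c2ccc(OCCCN3C(=O)/C=C/C(C)(C)C/C=C(\C)CC/C=C/3C)cc2)cc1` gives 2.92 ug/mL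

Compound 3 carries the highest number of the three: compound 2 sits within the scatter of it, while compound 1 lies beyond the scatter with a lower number. Compound 4 `COc1cc(/C=C/C(=O)c2ccc(OCCCN3C(=O)/C=C/C(C)(C)C/C=C(\C)CC/C=C/3C)cc2)cc(OC)c1OC` differs from compound 3 in one place: 3,4,5-trimethoxyphenyl in place of 4-methoxyphenyl on a double-bonded chain carbon bound to a double-bonded chain carbon. For the measured compounds named here, only one measured step bears on this change, a 2.7-fold higher number from compound 1 to compound 2 (0.44 log units; beyond the scatter), and it runs in the same direction, though it starts from 3-methoxyphenyl rather than 4-methoxyphenyl. A modest rise in the number is therefore expected for compound 4, amounting to a 2.1-fold higher number from compound 3 to compound 4 (0.31 log units; beyond the scatter). Compound 4 is estimated to give about 6 ug/mL in this assay, with a likely range from 2.5 ug/mL to 14 ug/mL.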

Compound 4, half-maximal inhibitory concentration: 0.71 ug/mL
The estimate for compound 4 lay 8.5-fold (0.93 log units) above the measured number, and the stated range ends above it.
By their numbers in this assay, from the lowest: compounds 4 and 1 (each within the scatter of the next); then compounds 2 and 3 (each within the scatter of the next).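

Moving to 3,4,5-trimethoxyphenyl gives a 4.1-fold lower number from compound 3 to compound 4 (0.61 log units; beyond the scatter) in this assay while the earlier step gave a 2.7-fold higher number from compound 1 to compound 2 (0.44 log units; beyond the scatter) so this group brings no fixed direction of change at this place. The two steps differ both in the methoxyphenyl group that leaves and in the rest of the molecule, so they cannot show which difference matters. Nothing available explains the opposite directions.

Still open, going by these compounds, is whether 4-methoxyphenyl would behave the same on the core of compound 1. On these data alone, how a 4-aminophenyl or 4-carboxyphenyl group would read at this place also remains unknown.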